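The source may hold more compounds than are shown below. What is called first, only, known or untested is meant among the compounds shown, and "the series" means these compounds.

Measured compounds:
compound 1, `CCN(CC)S(=O)(=O)c1ccc(S(=O)(=O)N2CCC[C@@H](C(=O)N[C@@H]3CCN(C(=O)OC(C)(C)C)C3)C2)cc1`: in a functional assay on MIA PaCa-2 cells (Homo sapiens) for inhibition, read by MTT assay, with a stated time of 3 days (on this read-out higher numbers stand for weaker inhibition and lower numbers for stronger inhibition), compound 1 gives > 10000 nM, a limit of the assay.
compound 2, `CCN1CC(NC(=O)[C@@H]2CCCN(S(=O)(=O)c3ccc(S(=O)(=O)N(CC)CC)cc3)C2)C1`: in this assay compound 2 gives > 10000 nM, also a limit.

Compound 2 therefore sits at the limit of > 10000 nM in this assay, at which 2 of the 2 values shown sit, with no number of its own. Compound 3, `CCN(CC)S(=O)(=O)c1ccc(S(=O)(=O)N2CCC[C@@H](C(=O)NC3CN(C(=O)OC(C)(C)C)C3)C2)cc1`, differs from it by tert-butoxycarbonyl in place of ethyl on an amine nitrogen in a ring. Among the measured compounds shown here, the only measured step, a step that the two limits leave unreadable from compound 1 to compound 2, is unreadable because both ends are limits, so it gives no size for this change. No movement beyond the scatter is expected, and compound 3 is expected to remain at the limit. Compound 3 is estimated at 20000 nM, within 8000 nM to 60000 nM. This corresponds to an expected step that the limit leaves unreadable from compound 2 to compound 3.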

Compound 3, half-maximal inhibitory concentration: > 10000 nM
Compound 3: a limit, no number (the forecaster's own chance of this, stated with the estimate: 85%); the middle value is on the limit's open side.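

Compound 1, compound 2 and compound 3 all sit at a limit in this assay, so no step between them can be read: the limit of > 10000 nM in this assay, at which 3 of the 3 values shown sit.

As far as these compounds go, whether any of these group changes alters inhibition, and by how much, stays open.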